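From 2-Methylbenzyl to 3-Fluorobenzyl: an Expected Step

The source may report more compounds than this note shows. Statements on the series, on what has been measured and on what is new or still open speak of the compounds shown alone.

Compound 1 `CCCCc1cnc(Cc2ccc(-c3ccccc3C(=O)O)cc2)[nH]1`: > 10000 nM
Compound 2 `CCCCc1cnc(CCCc2ccc(-c3ccccc3C(=O)O)cc2)[nH]1`: 382 nM
Compound 3 `Cc1ccccc1Cc1cnc(CCc2ccc(-c3ccccc3C(=O)O)cc2)[nH]1`: 9.3 nM

In an in vitro functional assay on cells for agonist activity at Bombesin receptor subtype-3 (Mus musculus), read by luminescence and calcium flux (on this read-out lower numbers stand for an effect already at smaller amounts and higher numbers for an effect only at larger amounts of compound), compound 3 has the lowest of the two numbers, and compound 2 sits far higher, a gap well beyond the usual scatter. For compound 1 the result is only a limit of the assay, not a number.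

Compound 4 `O=C(O)c1ccccc1-c1ccc(CCc2ncc(Cc3cccc(F)c3)[nH]2)cc1` has not yet been measured. It differs from compound 3 in one place: 3-fluorophenyl in place of 2-methylphenyl on a saturated chain carbon bound to an aromatic carbon. Going by the values given here, no measured pair shows this kind of exchange, so the expected step rests on nothing more than the size of the swapped group staying the same. A small step toward a somewhat higher number is expected, within or just beyond the scatter. The step expected is a 2.2-fold higher number from compound 3 to compound 4 (0.33 log units; beyond the scatter). Compound 4 is therefore estimated at 20 nM, likely between 4 nM and 100 nM.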

Compound 4, half-maximal effective concentration: 7.9 nM
For compound 4 the middle estimate is 2.5-fold (0.40 log units) above the measured one; the measured number falls inside the stated range.
By their numbers in this assay, from the lowest: compounds 4 and 3 (each within the scatter of the next); then compound 2. At a limit, above all of these: compound 1.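

In this assay, putting 3-fluorophenyl in place of 2-methylphenyl on a saturated chain carbon bound to an aromatic carbon gives a 1.2-fold lower number from compound 3 to compound 4 (0.07 log units; within the scatter). The low number of compound 3 is therefore not tied to 2-methylphenyl: a second substituted phenyl ring at this place gives a value within the scatter of it. Nothing measured here explains why the two groups read alike.

This exchange alters both the ring's substituent and where it sits, so the two changes cannot be told apart. As far as these compounds go, whether 3-methylphenyl, 2-fluorophenyl, plain phenyl or a phenyl ring carrying an amine would read the same stays open.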